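Furan-2-yl in Place of 4-Fluorophenyl: An Expectation

The source may hold more compounds than are shown below. What is called first, only, known or untested is meant among the compounds shown, and "the series" means these compounds.

Measured compounds:
compound 1, `CCN1CCN(c2cc(C)c3cc(NC(=O)c4ccc(F)cc4)ccc3n2)CC1`: in a functional assay on SK-BR-3 cells (Homo sapiens) for antiproliferative activity, read by MTT assay, with a stated time of 72 h (a higher number here means a weaker inhibitor, a lower number a stronger inhibitor), compound 1 gives 19800 nM
compound 2, `CCN1CCN(c2cc(C)c3cc(NC(=O)c4cccc(C)c4)ccc3n2)CC1`: in this assay compound 2 gives 13700 nM

Of the two measured compounds, compound 1 has the highest number in this assay, and compound 2 is the nearest to it. The step of a 1.4-fold lower number from compound 1 to compound 2 (0.16 log units; within the scatter) lies within the scatter, so the two compounds cannot be placed in order on these numbers.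

Compound 3, `CCN1CCN(c2cc(C)c3cc(NC(=O)c4ccco4)ccc3n2)CC1`, has not yet been measured. It differs from compound 1 in one place: furan-2-yl in place of 4-fluorophenyl on a carbonyl carbon. For the measured compounds named here, no measured step covers this particular exchange. Going by the values given here, the only step measured so far changes the group at the carbonyl carbon in another way, and that step, a 1.4-fold lower number from compound 1 to compound 2 (0.16 log units; within the scatter), stayed within the scatter. Nothing here points to a larger movement for the furan-2-yl group.

On that basis the account expects compound 3 to show no shift beyond the scatter in this assay, the expected step being a 1.1-fold lower number from compound 1 to compound 3 (0.04 log units; within the scatter). Compound 3 is therefore estimated at 18000 nM, with an expected range from 6000 nM to 50000 nM.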

Compound 3, half-maximal inhibitory concentration: 37500 nM
The estimate for compound 3 lay 2.1-fold (0.32 log units) below the measured number; the measured number falls inside the stated range.
By their numbers in this assay, from the lowest: compounds 2, 1 and 3 (each within the scatter of the next, the first and the last beyond it).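

In this assay, the position on the carbonyl carbon now holds a five-membered aromatic ring with a hetero atom, and the exchange of 4-fluorophenyl for furan-2-yl cannot be told from no change (a 1.9-fold higher number from compound 1 to compound 3 (0.28 log units; within the scatter)). The same position does give its first step beyond the scatter, though a modest one, when furan-2-yl takes the place of 3-methylphenyl (a 2.7-fold higher number from compound 2 to compound 3 (0.44 log units; beyond the scatter)). For the compounds shown here, compound 1 stays within the scatter of both other compounds, so the three groups do not fall into a clear order, and no measurement at hand explains the one step that can be read.

The compounds shown leave open whether the ring oxygen of furan-2-yl matters in itself, which thiophen-2-yl, with sulfur in the place of that oxygen, could begin to test. They also leave open how this position would respond to a group of a different kind, such as an amine or a carboxylic acid carried on the phenyl ring, or a saturated ring such as tetrahydrofuran-2-yl.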